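The source may report more compounds than this note shows. Statements on the series, on what has been measured and on what is new or still open speak of the compounds shown alone.

Working notes on the series in a functional assay (Cavia porcellus) with sulfonylurea receptors; K-ATP channels (Homo sapiens) as the target; on this read-out higher numbers stand for weaker inhibition and lower numbers for stronger inhibition. Three compounds carry numbers. Compound 1 `CC(O)(C(=O)Nc1ccc(S(=O)(=O)c2ccccc2)c(C#N)c1)C(F)(F)F` gives 3800 nM. Among the measured compounds shown here, compound 2 `COc1cc(NC(=O)C(C)(O)C(F)(F)F)ccc1S(=O)(=O)c1ccccc1` gives 5900 nM; the one step recorded, a 1.6-fold higher number from compound 1 to compound 2 (0.19 log units; within the scatter), changes a substituent on the aromatic ring and stays within the scatter. Compound 3 `CC(O)(C(=O)Nc1ccc(C(=O)c2ccccc2)cc1F)C(F)(F)F` gives 11000 nM, the highest of the three numbers, within the scatter of compound 2 and beyond it only against compound 1. Compound 4 `CC(O)(C(=O)Nc1ccc(C(=O)c2ccccc2)cc1O)C(F)(F)F` is not yet measured; it differs from compound 3 by hydroxy in place of fluoro on an aromatic carbon. For the measured compounds named here, no recorded step swaps fluoro for hydroxy; the only aromatic-substituent step, a 1.6-fold higher number from compound 1 to compound 2 (0.19 log units; within the scatter), was within the scatter, so the expected step of no change at the digits printed from compound 3 to compound 4 (within the scatter) is none beyond the scatter. Compound 4 is estimated at 11000 nM, range 4000 nM to 30000 nM.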

Compound 4, half-maximal inhibitory concentration: 15000 nM
Compound 4: middle estimate off by 1.4-fold (0.13 log units), on the low side; low and high end bracket the measured number.
By their numbers in this assay, from the lowest: compounds 1, 2, 3 and 4 (each within the scatter of the next, the first and the last beyond it).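

In this assay hydroxy in place of fluoro on an aromatic carbon, ortho to a large group and meta to a benzoyl group, gives a 1.4-fold higher number from compound 3 to compound 4 (0.13 log units; within the scatter) and so stays within the scatter. Among the compounds shown here, this is the first step recorded on this carbon, and it shows that a hydrogen-bond donor and acceptor can enter here without a change beyond the scatter. Open, from the compounds shown here alone, is whether an amine or a carboxylic acid on this carbon would move the number beyond the scatter, or whether hydroxy would do so in the core of compound 1. Nothing measured accounts for the size of this step.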